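Fluoropyridinyl ether swap on compound 2

A few compounds are considered here, and "the series" means these few. Any claim that something is new, unique, unknown or untested is made for them only; others in the source may bear on it.

In an ADME assay on the whole organism (plasma, Rattus norvegicus) for protein binding, using cassette dosing, at a dose of 1 mg/kg (a higher number here means a larger unbound share of the compound, a lower number a smaller unbound share), compound 1 `CC(C)Oc1ccc(/N=c2\[nH]c(=O)n(C[C@@H](O)CO)c(=O)n2Cc2ccc(Cl)cc2)cc1Cl` gives 0.001, and compound 2 `C[C@@H](Cn1c(=O)[nH]/c(=N\c2ccc(Oc3cncc(F)c3)cc2)n(Cc2ccc(Cl)cc2)c1=O)C(=O)O` gives 0.02. Compound 2 holds the higher of the two numbers, and the gap to compound 1 lies beyond the scatter. The two compounds differ in more than one place, so this gap cannot be assigned to any single group. Compound 3 `C[C@@H](Cn1c(=O)[nH]/c(=N\c2ccc(Oc3cccc(F)n3)cc2)n(Cc2ccc(Cl)cc2)c1=O)C(=O)O` keeps the rest of compound 2 and changes only the group on the oxygen: 6-fluoropyridin-2-yl in place of 5-fluoropyridin-3-yl on an oxygen on an aromatic ring. For the measured compounds named here, the two have the same atoms, joined differently, and no measured pair isolates a swap of this kind. A small downward step within the scatter of this assay is expected, with compound 2 at 0.02 as the only anchor. The estimated change is a 1.4-fold lower number from compound 2 to compound 3 (0.15 log units; within the scatter). The expected unbound fraction for compound 3 is 0.014, with an estimated range of 0.006 to 0.035.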

Compound 3, unbound fraction: 0.007
The estimate for compound 3 lay 2.0-fold (0.30 log units) above the measured number; the range from low to high includes it.
By their numbers in this assay, from the lowest: compound 1; then compound 3; then compound 2.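

In this assay, for the compounds shown here, the change on the oxygen gives a 2.9-fold lower number from compound 2 to compound 3 (0.46 log units; beyond the scatter), the first single-place step, and it shows that this position responds to a rearrangement of the same atoms. The 5-fluoropyridin-3-yl and 6-fluoropyridin-2-yl groups match in heavy atoms and in hydrogen-bond donor and acceptor counts, so these counts alone do not separate compound 2 from compound 3. Nothing available explains the direction or size of this step.

Going by these compounds, it remains open whether the lower number follows the 6-fluoropyridin-2-yl group as a whole or either of its parts, which a plain pyridin-2-yl or a 6-methoxypyridin-2-yl group on the same oxygen could help separate. On these data alone, it is also open whether the step carries over to compounds without the carboxylic acid of compound 2.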